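The source may hold more compounds than are shown below. What is called first, only, known or untested is meant among the compounds shown, and "the series" means these compounds.

Compound 3 `COc1cc2c(cc1N1C[C@@H](C)N[C@@H](C)C1)N(S(=O)(=O)Cc1cccc(I)c1)CC2` reaches 0.8 in a functional assay with growth hormone secretagogue receptor type 1 (Homo sapiens) as the target (a lower number here means a smaller maximal response, a higher number a larger maximal response), the second highest of the three numbers measured. Compound 1 `COc1cc2c(cc1N1C[C@@H](C)N(C)[C@@H](C)C1)N(S(=O)(=O)c1cccc(Br)c1)CC2` gives 0.7 in this assay, which lies within the scatter of compound 3. For the measured compounds named here, compound 2 `COc1cc2c(cc1N1C[C@@H](C)N[C@@H](C)C1)N(S(=O)(=O)c1ccc3ccccc3c1)CC2` gives 1 in this assay, and the only single-point step among the measured compounds, a number 0.20 lower from compound 2 to compound 3 (beyond the scatter), was a modest loss beyond the scatter. Compound 4 `COc1cc2c(cc1N1C[C@@H](C)N[C@@H](C)C1)N(S(=O)(=O)CCc1ccccc1Cl)CC2` departs from compound 3 at the same sulfonyl position: 2-chlorobenzyl in place of 3-iodophenyl on a saturated chain carbon bound to a sulfonyl sulfur. That earlier step is the only one that bears on this change, and it suggests a small downward drift or none beyond the scatter. The step from compound 3 is expected to be a number 0.050 lower from compound 3 to compound 4 (within the scatter). Compound 4 is therefore estimated at 0.75, with a range from 0.55 to 0.95.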

Compound 4, intrinsic activity: the largest response reached, as a fraction of the reference agonist's: 0.9
Compound 4: the middle estimate sits 0.15 below what was measured; low and high end bracket the measured number.
By their numbers in this assay, from the lowest: compounds 1, 3, 4 and 2 (each within the scatter of the next, the first and the last beyond it).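

In this assay, 2-(2-chlorophenyl)ethyl on the sulfonyl sulfur sits within the scatter of both neighbours: 3-iodobenzyl (a number 0.10 higher from compound 3 to compound 4 (within the scatter)) and naphthalen-2-yl (a number 0.10 lower from compound 2 to compound 4 (within the scatter)). Compound 4 thus falls within the scatter of both compound 2 and compound 3, even though those two differ beyond it, so this group cannot be placed with either. No evidence on the cause is available here. Still open, from the compounds shown here alone, is how a plain 2-phenylethyl group, or an amine or a carboxylic acid in place of the chlorine, would read in this assay.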